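Benzyl Substitution on the Amide Nitrogen and Cell Tolerance

A few compounds are considered here, and "the series" means these few. Any claim that something is new, unique, unknown or untested is made for them only; others in the source may bear on it.

Compound 1 `CC(C)(C)NC(=O)COC(=O)c1ccc([N+](=O)[O-])o1` is the parent of this small set. In an ADME assay on MT4 cells (Homo sapiens) for cytotoxicity, read by MTT assay, with a stated time of 3 days (a lower number here means that less compound is tolerated, a higher number that more compound is tolerated), compound 1 gives > 100000 nM, which is a limit of the assay rather than a measured number. Two companions share its core, each carrying a further group on the amide-type nitrogen. Compound 2 `CC(C)(C)N(CCC(=O)c1ccccc1)C(=O)COC(=O)c1ccc([N+](=O)[O-])o1` is recorded in this assay as "not active" (no number reported), with no number behind it. Compound 3 `CC(C)(C)N(Cc1ccc([N+](=O)[O-])cc1)C(=O)COC(=O)c1ccc([N+](=O)[O-])o1` gives in this assay > 100000 nM, again a limit of the assay. All three results therefore lie at or beyond the edge of what this assay can resolve, and the limit of > 100000 nM in this assay, at which 2 of the 3 values shown sit, holds two of them.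

The unmeasured compound 4 `CC(C)(C)N(Cc1ccc(F)cc1)C(=O)COC(=O)c1ccc([N+](=O)[O-])o1` differs from compound 1 by 4-fluorobenzyl in place of hydrogen on an amide-type nitrogen. For the measured compounds named here, no step between measured compounds is available to calibrate this change. Since compound 1 and compound 3 both rest at the limit of > 100000 nM in this assay, at which 2 of the 3 values shown sit, no step beyond the usual scatter is expected from compound 1 to compound 4 in this assay, and the expected step is a step that the limit leaves unreadable from compound 1 to compound 4. Compound 4 is accordingly expected to give 150000 nM, within 60000 nM to 400000 nM, most likely reported again only as a limit.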

Compound 4, half-maximal cytotoxic concentration: > 100000 nM
Compound 4 ended at the assay's limit (the forecaster's own chance of this, stated with the estimate: 80%); the middle value does not contradict the limit.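

No step can be read between compound 1, compound 3 and compound 4, since each of these three results is a limit rather than a number, and so is any comparison among them: the limit of > 100000 nM in this assay, at which 3 of the 4 values shown sit.

The compounds shown leave open at what concentration any of them harms the cells, and whether 4-fluorobenzyl on the amide-type nitrogen changes cell tolerance at all.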